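A few compounds are considered here, and "the series" means these few. Any claim that something is new, unique, unknown or untested is made for them only; others in the source may bear on it.

The three measured compounds share a core in which a nitrile-bearing double bond carries a carbonyl group. Compound 1 `N#C/C(=C\c1c[nH]c2ccccc12)C(=O)c1c[nH]c2ccccc12` gives 9300 nM in a functional assay on A2780 cells (Homo sapiens) for inhibition, read by MTT assay, with a stated time of 72 h; a higher number here means a weaker inhibitor of growth, a lower number a stronger inhibitor of growth. Compound 3 `COc1ccc(CNC(=O)/C(C#N)=C/c2ccc(C)o2)cc1` gives 60000 nM in this assay. Compound 2 `N#C/C(=C\c1ccc[nH]1)C(=O)NCc1ccc(Cl)c(Cl)c1` reaches only a limit of this assay, > 50000 nM, and that limit is the point described by the limit of > 50000 nM in this assay, at which 1 of the 3 values shown sits. Because compound 2 is recorded only as > 50000 nM, its standing cannot be fixed against the other two numbers; it sits at the weak end of what the measurements show, with no value of its own.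

Compound 4 `N#C/C(=C\c1ccc(Cl)cc1)C(=O)NCc1ccc(Cl)c(Cl)c1` differs from compound 2 by 4-chlorophenyl in place of 1H-pyrrol-2-yl on a double-bonded chain carbon bound to a double-bonded chain carbon. Among the measured compounds shown here, no step between measured compounds bears on this change, so its size can only be guessed. In this assay the step from compound 2 to compound 4 is expected to be an at least 1.2-fold lower number from compound 2 to compound 4 (0.09 log units; that floor lies within the scatter), that is, no movement beyond the scatter is expected in either direction, and a second limit would not be surprising. Compound 4 is therefore expected to give about 40000 nM, somewhere between 10000 nM and 100000 nM, because compound 3 gives 60000 nM and shows how weak this core tends to be.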

Compound 4, concentration for 50% growth inhibition: 32000 nM
Compound 4: middle estimate off by 1.3-fold (0.10 log units), on the high side, within the range that was stated.
By their numbers in this assay, from the lowest: compound 1; then compounds 4 and 3 (each within the scatter of the next).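

In this assay, among the compounds shown here, placing 4-chlorophenyl in place of 1H-pyrrol-2-yl on a double-bonded chain carbon bound to a double-bonded chain carbon gives an at least 1.5-fold lower number from compound 2 to compound 4 (0.19 log units; that floor lies within the scatter), the first step that can be read at this position, and it gives compound 4 a number of its own, 32000 nM. Compound 2 stands only at a limit of the assay, > 50000 nM, and not at a number. The step is therefore a floor and not a size, and this floor does not show a movement beyond the scatter, because one end of it rests on that limit: the limit of > 50000 nM in this assay, at which 1 of the 4 values shown sits.

The compounds shown leave open whether the true step from the 1H-pyrrol-2-yl group to the 4-chlorophenyl group reaches beyond the scatter or stays within it. They also leave open how an unsubstituted phenyl ring, a 4-methoxyphenyl group or a 4-aminophenyl group would read at this place, and so whether the chlorine or the six-membered aromatic ring of carbon accounts for the number of compound 4.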